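Oxane ring replaced by a methoxypropyl chain: stability notes

The compounds below may be only part of what the source reports. "The series", "measured", "known", "first", "only" and "open" are said of these compounds alone.

Measured compounds in an ADME assay on microsomes from liver (Rattus norvegicus) for metabolic stability, with a stated time of 10 min; a higher number here means that more of the compound is left, a lower number that less of the compound is left:
compound 1 `COc1ccccc1-n1nc([C@@H]2CCO[C@H](C(C)C)C2)cc1-c1ccc(Cl)cc1`: 21%
compound 2 `COc1ccccc1-n1nc(C2CC(C)(C)OC(C)(C)C2)cc1-c1ccc(Cl)cc1`: 96%
compound 3 `COc1ccccc1-n1nc(C2C[C@H](C)O[C@@H](C)C2)cc1-c1ccc(Cl)cc1`: 14%

Compound 3 gives the lowest of the three numbers, though its gap to compound 1 is within the scatter; only compound 2 stands clearly apart from it. The next compound is compound 4 `COCCCc1cc(-c2ccc(Cl)cc2)n(-c2ccccc2OC)n1`. Its difference from compound 3: 3-methoxypropyl in place of 2,6-dimethyloxan-4-yl on an aromatic carbon. Within the data shown here, the steps that bear on this change are a number 82 percentage points lower from compound 2 to compound 3 (beyond the scatter) and a number 7 percentage points lower from compound 1 to compound 3 (within the scatter), both exchanges of one oxane for another on the same aromatic carbon. Among the measured compounds shown here, no measured step replaces the ring by a chain, so the direction of the change is uncertain. For compound 4 the expected step is estimated as a number 11 percentage points higher from compound 3 to compound 4 (beyond the scatter). The expected value for compound 4 is estimated as 25%, within 5% to 60%.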

Compound 4, percent of the compound remaining: 4%
Estimate against measurement, compound 4: 21 percentage points above; measured number outside the range, below it.
By their numbers in this assay, from the lowest: compounds 4, 3 and 1 (each within the scatter of the next, the first and the last beyond it); then compound 2.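

Replacing the ring by 3-methoxypropyl gives a number 10 percentage points lower from compound 3 to compound 4 (within the scatter) in this assay and so cannot be told apart from the 2,6-dimethyloxan-4-yl group. Against the other two oxanes the same chain gives a number 17 percentage points lower from compound 1 to compound 4 (beyond the scatter) and a number 92 percentage points lower from compound 2 to compound 4 (beyond the scatter) in this series. An oxane ring is therefore not needed for a low number at this position, and the open chain recovers none of the high number of compound 2.

No measurement here gives a cause for these steps. On these data alone, whether a 3-methoxy-3-methylbutyl chain would follow compound 2 or compound 4 stays open.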